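A few compounds are considered here, and "the series" means these few. Any claim that something is new, unique, unknown or untested is made for them only; others in the source may bear on it.

In a functional assay on A549 cells (Homo sapiens) for inhibition, read by MTT assay, with a stated time of 72 h (on this read-out higher numbers stand for weaker inhibition and lower numbers for stronger inhibition), compound 2 `Oc1ccc(-c2nnc(SCCCN3CCN(c4nc5ccccc5s4)CC3)o2)cc1` gives 62100 nM and compound 1 `Brc1ccc(-c2nnc(SCCCN3CCN(c4nc5ccccc5s4)CC3)o2)cc1` gives 62500 nM so the two stand level within the scatter. Compound 3 `c1ccc(-c2nnc(SCCCN3CCN(c4nc5ccccc5s4)CC3)o2)cc1` differs from compound 2 by hydrogen in place of hydroxy on an aromatic carbon. For the measured compounds named here, the only measured step that bears on this is a 1.0-fold lower number from compound 1 to compound 2 (0.00 log units; within the scatter) on that same aromatic carbon, a change within the scatter. No step beyond the scatter is therefore expected in this assay and the estimated step is a 1.1-fold lower number from compound 2 to compound 3 (0.05 log units; within the scatter) for this exchange. Compound 3 is estimated at 55000 nM (expected range 22000 nM to 120000 nM).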

Compound 3, half-maximal inhibitory concentration: 257000 nM
Compound 3: the middle estimate sits 4.7-fold (0.67 log units) below what was measured, and the stated range ends below it.
By their numbers in this assay, from the lowest: compounds 2 and 1 (each within the scatter of the next); then compound 3.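

Removing the group altogether is what registers at this position: a 4.1-fold higher number from compound 2 to compound 3 (0.62 log units; beyond the scatter) and a 4.1-fold higher number from compound 1 to compound 3 (0.61 log units; beyond the scatter) in this assay are both beyond the scatter and both run toward weaker inhibition. Hydroxy and bromo, which stood level, thus share an edge over plain hydrogen on this aromatic carbon, something the exchange between them could not show. Nothing measured here explains this.

Going by these compounds, whether an amine, a methoxy group or a carboxylic acid on the same carbon would match compound 1 and compound 2 or fall back toward compound 3 remains open.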